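Tetrahydronaphthyl in place of 4-iodophenyl: working notes

A few compounds are considered here, and "the series" means these few. Any claim that something is new, unique, unknown or untested is made for them only; others in the source may bear on it.

Measured in an ADME assay on BJ cells (Homo sapiens) for cytotoxicity, with a stated time of 72 h; a higher number here means that more compound is needed for the effect, a lower number that less compound is needed:
- compound 1 `Cc1nn(-c2ccccc2)c2nc(-c3ccc(C(F)(F)F)cc3)c(C#N)c(-c3ccccc3O)c12`: 22900 nM
- compound 2 `Cc1nn(-c2ccccc2)c2nc(-c3ccc(I)cc3)c(C#N)c(-c3ccccc3O)c12`: 19000 nM

Compound 2 stands level with compound 1 in this assay, and no order can be read between them. Compound 3 `Cc1nn(-c2ccccc2)c2nc(-c3ccc4c(c3)CCCC4)c(C#N)c(-c3ccccc3O)c12` is still to be measured. It carries 1,2,3,4-tetrahydronaphthalen-6-yl in place of 4-iodophenyl on an aromatic carbon, next to the ring nitrogen and ortho to a cyano group: 1,2,3,4-tetrahydronaphthalen-6-yl in place of 4-iodophenyl on an aromatic carbon. Among the measured compounds shown here, only one measured step bears on this, and only loosely, since it exchanged trifluoromethyl for iodo on the group that now leaves whole. For the measured compounds named here, with a 1.2-fold lower number from compound 1 to compound 2 (0.08 log units; within the scatter) as the sole guide, no step beyond the scatter is expected, and no direction can be given. The expected step is a 1.1-fold higher number from compound 2 to compound 3 (0.02 log units; within the scatter). Compound 3 is estimated at 20000 nM, with an expected range of 10000 nM to 40000 nM.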

Compound 3, half-maximal effective concentration: > 20000 nM
Compound 3 gave a limit, no number; the forecaster's own chance of this, stated with the estimate: 15%; the middle value lies on the limit itself.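

In this assay, compound 3 gives a limit and not a number: the limit of > 20000 nM in this assay, at which 1 of the 3 values shown sits.

On the aromatic carbon next to the ring nitrogen and ortho to a cyano group, 1,2,3,4-tetrahydronaphthalen-6-yl in place of 4-iodophenyl gives an at least 1.0-fold higher number from compound 2 to compound 3 (0.02 log units; that floor lies within the scatter), so no order can be read. Unlike the earlier exchange of trifluoromethyl for iodo, this change replaces the whole group, and the added non-aromatic carbon ring brings no readable shift towards less compound being needed.

Going by these compounds, the true value of compound 3 remains unknown, and the step from compound 1 to compound 3 cannot be read. Also open, on these data alone, is how an amine or a carboxylic acid on this aromatic ring, or a longer chain in place of the ring, would read in this assay.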